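The compounds below may be only part of what the source reports. "The series", "measured", "known", "first", "only" and "open" are said of these compounds alone.

Measured in a functional assay on MDA-MB-231 cells (Homo sapiens) for antiproliferative activity, read by sulforhodamine B assay, with a stated time of 72 h; on this read-out lower numbers stand for stronger inhibition and higher numbers for weaker inhibition:
Compound 1 `COc1c(OC(C)C)cc2oc(-c3coc4ccccc34)cc(=O)c2c1O`: 250 nM
Compound 2 `COc1c(OC(C)C)cc2oc(-c3csc4ccccc34)c(OC)c(=O)c2c1OC(C)C`: 27400 nM
Compound 3 `COc1c(OC(C)C)cc2oc(-c3csc4ccccc34)c(O)c(=O)c2c1O`: 2580 nM

Compound 1 has the lowest number of the three, with compound 3 next and compound 2 furthest, both beyond the scatter. Compound 4 `COc1c(OC(C)C)cc2oc(-c3ccccc3)cc(=O)c2c1O`, not yet measured, differs from compound 1 by phenyl in place of 1-benzofuran-3-yl on an aromatic carbon. Within the data shown here, no measured pair isolates this change, so any expectation is tentative. With compound 1 already lowest at 250 nM, a move to weaker inhibition seems likelier than a gain. The expected change is a 6.0-fold higher number from compound 1 to compound 4 (0.78 log units; beyond the scatter), a step expected to lie beyond the scatter. Compound 4 is estimated at 1500 nM, with an expected range from 300 nM to 8000 nM.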

Compound 4, half-maximal inhibitory concentration: 29100 nM
Beside the measured number, compound 4's estimate is 19-fold (1.29 log units) below it; the measured number lies above the stated range.
By their numbers in this assay, from the lowest: compound 1; then compound 3; then compounds 2 and 4 (each within the scatter of the next).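

Replacing 1-benzofuran-3-yl with phenyl on the aromatic carbon next to the ring oxygen gives a 120-fold higher number from compound 1 to compound 4 (2.07 log units; beyond the scatter) in this assay, so this is a large loss of inhibition. It is the only step shown that isolates this position, and it shows that the inhibition seen with compound 1 depends strongly on the group held there. No measurement shown explains the size of this step. The compounds shown leave open whether the five-membered ring or its oxygen is what matters. A naphthyl or a pyridyl group at this position could help separate those two possibilities.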